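The source may hold more compounds than are shown below. What is called first, only, known or untested is meant among the compounds shown, and "the series" means these compounds.

Three related compounds, compound 1 `Nc1ncnc2c1c(-c1cnc3[nH]ccc3c1)nn2CCCC(=O)NO`, compound 3 `Nc1ncnc2c1c(-c1cnc3[nH]ccc3c1)nn2CCCCCCC(=O)NO` and compound 2 `Nc1nc2cc(-c3nn(CCCCCC(=O)NO)c4ncnc(N)c34)ccc2o1`, share one core and carry a hydroxycarbamoyl group on a chain of differing length. In a functional assay on A549 cells (Homo sapiens) for inhibition, read by MTT assay, with a stated time of 72 h (a lower number here means a stronger inhibitor, a higher number a weaker inhibitor), compound 3 gives 50000 nM. For compound 1 only a limit is known: in this assay compound 1 gives > 150000 nM. Compound 2 also stops at a limit, giving > 100000 nM in this assay. Among the compounds with values here, the single measured step, an at least 3.0-fold lower number from compound 1 to compound 3 (0.47 log units; beyond the scatter), shows that a longer chain lowers the number. Compound 4 `Nc1nc2cc(-c3nn(CCC(=O)NO)c4ncnc(N)c34)ccc2o1` moves the other way: hydroxycarbamoyl in place of 3-(hydroxycarbamoyl)propyl on a saturated chain carbon, two bonds along the chain from an aromatic nitrogen. Because compound 2 already sits at the limit of > 100000 nM in this assay, at which 1 of the 3 values shown sits, a shorter chain is expected to yield only a limit again. The expected step is a step that the limit leaves unreadable from compound 2 to compound 4. Compound 4 is estimated at 200000 nM, within 100000 nM to 500000 nM.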

Compound 4, half-maximal inhibitory concentration: > 150000 nM
Compound 4 was reported as a limit (the forecaster's own chance of this, stated with the estimate: 85%); the middle value lies beyond the limit too.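

Compound 2 and compound 4 both stop at a limit in this assay, so the step between them cannot be read. The compounds shown leave open whether the shorter chain of compound 4 changes the number at all.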